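The source may report more compounds than this note shows. Statements on the series, on what has been measured and on what is new or still open speak of the compounds shown alone.

Compound 3 `CC(=O)c1ccc(Nc2ccc3c(c2)C(=O)N(C2CCC(=O)NC2=O)C3=O)cc1` gives -2% in an assay on FRT-Jurkat cells for inhibition of nuclear factor NF-kappa-B complex (Homo sapiens), read by flow cytometry, with a stated time of 24 h, tested at 10 uM; a higher number here means more inhibition at the concentration tested (going by the name of the read-out), a lower number less inhibition. This puts compound 3 level with compound 2 `CN(c1ccccc1)c1ccc2c(c1)C(=O)N(C1CCC(=O)NC1=O)C2=O`, which gives -2% in this assay, and the two sit together below compound 1 `O=C1CCC(N2C(=O)c3ccc(Nc4ccccn4)cc3C2=O)C(=O)N1`, which gives 9% in this assay. The steps from compound 1 are a number 11 percentage points lower from compound 1 to compound 3 (beyond the scatter) and a number 11 percentage points lower from compound 1 to compound 2 (beyond the scatter); in each the pyridin-2-yl-bearing compound 1 is left for a phenyl-type group on the nitrogen, and in each the reading falls by the same modest amount.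

Compound 4 `Cc1ccccc1Nc1ccc2c(c1)C(=O)N(C1CCC(=O)NC1=O)C2=O` differs from compound 3 by 2-methylphenyl in place of 4-acetylphenyl on a nitrogen on an aromatic ring. Going by the values given here, no measured step exchanges one phenyl-type group for another on this nitrogen; the two measured steps only show that leaving pyridin-2-yl for either methyl(phenyl)amino or 4-acetylphenyl costs the same modest amount. Compound 4 carries a third phenyl-type group, and no drop beyond the scatter is expected, nor a return toward compound 1. The step of a number 2 percentage points higher from compound 3 to compound 4 (within the scatter) is therefore expected to stay within the scatter. For compound 4 the estimate in this assay is 0%, with a range from -12% to 12%.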

Compound 4, a percentage reported as inhibition, at one concentration (the size of the read-out at that concentration, not a potency): 2%
Estimate against measurement, compound 4: 2 percentage points below; the range from low to high includes it.
By their numbers in this assay, from the lowest: compounds 2, 3, 4 and 1 (each within the scatter of the next, the first and the last beyond it).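

In this assay, exchanging 4-acetylphenyl for 2-methylphenyl on the nitrogen gives a number 4 percentage points higher from compound 3 to compound 4 (within the scatter), and the change to (2-methylphenyl)amino from methyl(phenyl)amino gives a number 4 percentage points higher from compound 2 to compound 4 (within the scatter), so these phenyl-type groups are not separated in this assay. Against the pyridin-2-yl of compound 1, 2-methylphenyl gives a number 7 percentage points lower from compound 1 to compound 4 (within the scatter), so leaving pyridin-2-yl for a phenyl-type group does not always produce a step beyond the scatter, and compounds 2 and 3 are the cases that do. No supporting data are available to explain these readings.

Still open, from the compounds shown here alone, is whether a piperidine or morpholine in place of the aryl group on this nitrogen, or a carboxylic acid on the phenyl ring, would give a reading clearly above that of compound 1 at 9%. The potency of these compounds also remains open, as each reading comes from a single concentration.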